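This account rests on a few compounds, and the source may have more. Where it says the series, first, only, none or still open, it means among the compounds named here.

Measured compounds:
compound 1 `C#CCNC1CCc2c(SCCc3cccc(C(F)(F)F)c3)cccc21` – 280 nM
compound 2 `C#CCNC1CCc2c(SCCc3cccc(F)c3)cccc21` – 7810 nM
compound 3 `C#CCNC1CCc2c(SCc3ccc(Cl)cc3Cl)cccc21` – 22300 nM

All three were tested in an ADME assay on isolated protein for inhibition of Amine oxidase [flavin-containing] B (Homo sapiens); a higher number here means a weaker inhibitor, a lower number a stronger inhibitor. Compound 2 gives the second highest number of the three, with compound 3 nearest and compound 1 far below it. The unmeasured compound 4 `C#CCNC1CCc2c(SCCc3ccc(Cl)c(Cl)c3)cccc21` keeps the whole core and the two-carbon chain of compound 2 and changes only the ring at its end: 3,4-dichlorophenyl in place of 3-fluorophenyl on a saturated chain carbon, two bonds along the chain from a sulfur.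

Going by the values given here, only one measured step touches the same ring with the same chain in place: a 28-fold higher number from compound 1 to compound 2 (1.45 log units; beyond the scatter). It shows that swapping one group on that ring for another can move the number well beyond the scatter in this assay. Compound 3 carries chlorines, but on a shorter chain and in a different arrangement, so its value is only a loose hint; it sits higher than compound 2. The exchange of a single fluorine for two chlorines is a sizeable alteration of the ring, so a step beyond the scatter is expected, most likely toward a lower number, as the step from compound 2 to compound 4 is estimated at a 5.2-fold lower number from compound 2 to compound 4 (0.72 log units; beyond the scatter). Compound 4 is therefore expected to give about 1500 nM, within a range of 400 nM to 6000 nM.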

Compound 4, half-maximal inhibitory concentration: 2820 nM
Compound 4: middle estimate off by 1.9-fold (0.27 log units), on the low side; the range from low to high includes it.
By their numbers in this assay, from the lowest: compound 1; then compound 4; then compound 2; then compound 3.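

In this assay, placing 3,4-dichlorophenyl in place of 3-fluorophenyl on a saturated chain carbon, two bonds along the chain from a sulfur, gives a 2.8-fold lower number from compound 2 to compound 4 (0.44 log units; beyond the scatter). Going by these compounds alone, the earlier step showed that the number rises beyond the scatter when trifluoromethyl gives way to fluoro; this one shows that a ring carrying two chlorines also gives a lower number than the fluoro ring, so trifluoromethyl is not the only group here that does so, although compound 4 at 2820 nM still sits well above compound 1 at 280 nM. No measurement shown explains why either ring change moves the number.

Going by these compounds, it remains open whether one chlorine alone would give the same result as two, and how a methoxy group or a nitrile on the same ring would compare. On these data alone, compound 3 differs from compound 4 in both its chain and the arrangement of its chlorines, so the contribution of chain length cannot be separated from that of the ring, and a longer chain also remains untested.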